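This account rests on a few compounds, and the source may have more. Where it says the series, first, only, none or still open, it means among the compounds named here.

Measured so far:
Compound 1 `N/C(=N\C(=O)NC1CCCCC1)Nc1cccc(-c2csc(N)n2)c1` gives 4470 nM in an assay on membranes from Sf9 cells for displacement of a labelled ligand from histamine H2 receptor (Homo sapiens), read by scintillation counting, with a stated time of 60 min; a lower number here means a stronger inhibitor, a higher number a weaker inhibitor.
Compound 2 `Cc1nc(N)sc1CCCN/C(N)=N/C(=O)NC(C)c1cccc(F)c1` gives 2.04 nM in this assay.
Compound 3 `Cc1nc(N)sc1CCCN/C(N)=N/C(=O)N[C@@H](C)c1ccccc1` gives 51.3 nM in this assay.

Compound 2 stands lowest of the three numbers. Its nearest neighbour is compound 3, whose value in this assay is far higher, beyond the scatter; compound 1 lies furthest away, with a value that is higher still. Compound 2 and compound 3 share the same core and differ at the ring on the saturated chain carbon, where compound 3 carries a plain ring and compound 2 the 3-fluorophenyl; the two values alone show that this part of the molecule is not indifferent.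

Compound 4 `COc1ccc(C(C)NC(=O)/N=C(\N)NCCCc2sc(N)nc2C)cc1` has not yet been measured. It differs from compound 2 in one place: 4-methoxyphenyl in place of 3-fluorophenyl on a saturated chain carbon bound to an amide-type nitrogen and a saturated chain carbon. Among the compounds with values here, no measured pair shows this change directly, so the step from compound 2 to compound 4 in this assay is expected to be a moderate rise, a little beyond the scatter, a 4.9-fold higher number from compound 2 to compound 4 (0.69 log units; beyond the scatter). Compound 4 is therefore estimated to give 10 nM in this assay, somewhere between 2 nM and 50 nM.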

Compound 4, inhibition constant: 37.2 nM
The estimate for compound 4 lay 3.7-fold (0.57 log units) below the measured number, and the stated range covers the measured number.
By their numbers in this assay, from the lowest: compound 2; then compounds 4 and 3 (each within the scatter of the next); then compound 1.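

Within the data shown here, exchanging 3-fluorophenyl for 4-methoxyphenyl on the saturated chain carbon gives, in this assay, an 18-fold higher number from compound 2 to compound 4 (1.26 log units; beyond the scatter), the first directly readable step at this position. It shows that the value is sensitive to this exchange between two substituted aromatic rings, although the entering group differs from the leaving one by only a little in size and by one hydrogen-bond acceptor. Nothing measured here explains the size of this step.

Because the fluorine and the methoxy differ in both identity and ring position, this single pair cannot show how much of the step belongs to either difference. It also leaves open how other groups at this position, such as chlorophenyl or hydroxyphenyl, would compare with compound 2 in this assay.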